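Acylguanidine series: tert-butoxy in place of phenylsulfanyl

The source may hold more compounds than are shown below. What is called first, only, known or untested is meant among the compounds shown, and "the series" means these compounds.

Of the compounds shown here, three on the shared core have been measured in a functional assay for inhibition of sodium/hydrogen exchanger (Oryctolagus cuniculus); on this read-out higher numbers stand for weaker inhibition and lower numbers for stronger inhibition. Compound 1 `Cc1cc(-c2ccco2)c(S(C)(=O)=O)cc1C(=O)N=C(N)N` gives 16 nM. Compound 2 `CCSc1cc(C)c(C(=O)N=C(N)N)cc1S(C)(=O)=O` gives 5.9 nM. Compound 3 `Cc1cc(Sc2ccccc2)c(S(C)(=O)=O)cc1C(=O)N=C(N)N` gives 14 nM. Going by the values given here, on these numbers compound 3 stands second highest of the three: the step of a 1.1-fold lower number from compound 1 to compound 3 (0.06 log units; within the scatter) is within the scatter, so compound 1 and compound 3 cannot be told apart, while the step of a 2.4-fold higher number from compound 2 to compound 3 (0.38 log units; beyond the scatter) is beyond it, leaving compound 2 as the compound with the lowest number so far.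

Compound 4 `Cc1cc(OC(C)(C)C)c(S(C)(=O)=O)cc1C(=O)N=C(N)N` carries the change (tert-butoxy in place of phenylsulfanyl on an aromatic carbon). Among the compounds with values here, two measured steps bear on it. The step of a 2.4-fold higher number from compound 2 to compound 3 (0.38 log units; beyond the scatter) shows that the phenyl on the sulfur gives a modestly higher number than the ethyl, and the step of a 2.7-fold lower number from compound 1 to compound 2 (0.43 log units; beyond the scatter) shows that ethylsulfanyl gives a modestly lower number than furan-2-yl. In both cases the group without a ring at this position went with the lower number, although with three compounds this is a thin basis. Since tert-butoxy also has no ring, a modest step toward a lower number is expected in this assay, of the size a 1.8-fold lower number from compound 3 to compound 4 (0.24 log units; within the scatter). Compound 4 is therefore estimated at 8 nM, with a range from 3 nM to 22 nM.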

Compound 4, half-maximal inhibitory concentration: 9.4 nM
Compound 4: the middle estimate sits 1.2-fold (0.07 log units) below what was measured; measured number inside the range.
By their numbers in this assay, from the lowest: compounds 2, 4, 3 and 1 (each within the scatter of the next, the first and the last beyond it).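

In this assay tert-butoxy, on the aromatic carbon ortho to the methylsulfonyl group, cannot be told apart from any of the three groups seen there so far, as all three new steps lie within the scatter (a 1.5-fold lower number from compound 3 to compound 4 (0.17 log units; within the scatter); a 1.6-fold higher number from compound 2 to compound 4 (0.20 log units; within the scatter); a 1.7-fold lower number from compound 1 to compound 4 (0.23 log units; within the scatter)). Going by these compounds alone, the earlier compounds left ethylsulfanyl in compound 2 as the only group without a ring, and it stood beyond the scatter from both ring-bearing compounds; compound 4 also has no ring but separates from neither compound 1 nor compound 3, so it goes against sorting this position by ring or no ring. No measurement at hand accounts for compound 4 falling within the scatter of all three, and the change itself offers no explanation on these data.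

The oxygen and sulfur links remain unseparated here, since tert-butoxy differs from ethylsulfanyl in more than the linking atom, and an ethoxy group would pair directly with compound 2. Also open, from the compounds shown here alone, is whether a dimethylamino group, a carboxylic acid or a longer alkoxy chain at this position would stand beyond the scatter from these four compounds.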